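A ureido group replaces carbamoyl on the sulfur chain

This account rests on a few compounds, and the source may have more. Where it says the series, first, only, none or still open, it means among the compounds named here.

Of the compounds shown here, three sharing one core have been measured in a functional assay on HT cells (Homo sapiens) for antiproliferative activity, read by fluorescence, with a stated time of 72 h; on this read-out higher numbers stand for weaker inhibition of growth and lower numbers for stronger inhibition of growth. Compound 1 `CSc1nc(NCc2ccc(-c3ccccn3)cc2)c2[nH]nc(C(C)C)c2n1` gives 783 nM, compound 2 `CC(C)c1n[nH]c2c(NCc3ccc(-c4ccccn4)cc3)nc(SC3CCCC3O)nc12` gives 567 nM, and compound 3 `CC(C)c1n[nH]c2c(NCc3ccc(-c4ccccn4)cc3)nc(SCCC(N)=O)nc12` gives 120 nM, the lowest number of the three. Compound 4 `CC(C)c1n[nH]c2c(NCc3ccc(-c4ccccn4)cc3)nc(SCCNC(N)=O)nc12` has not yet been measured. It carries ureido in place of carbamoyl on a saturated chain carbon, two bonds along the chain from a sulfur.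

The measured steps that bear on this change all alter the group on the sulfur. Two are modest and beyond the scatter: a 6.5-fold lower number from compound 1 to compound 3 (0.81 log units; beyond the scatter) and a 4.7-fold lower number from compound 2 to compound 3 (0.67 log units; beyond the scatter). A third, a 1.4-fold lower number from compound 1 to compound 2 (0.14 log units; within the scatter), stays within it. Among the measured compounds shown here, no measured compound carries the ureido group, so the data offer no direct reading of it. Compound 3, at 120 nM, remains the closest guide, and no step beyond the scatter is expected in this assay. The estimated change is a 1.3-fold higher number from compound 3 to compound 4 (0.10 log units; within the scatter). Compound 4 is expected at about 150 nM, with an estimated range of 60 nM to 400 nM.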

Compound 4, concentration for 50% growth inhibition: 240 nM
Beside the measured number, compound 4's estimate is 1.6-fold (0.20 log units) below it; low and high end bracket the measured number.
By their numbers in this assay, from the lowest: compounds 3 and 4 (each within the scatter of the next); then compounds 2 and 1 (each within the scatter of the next).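

In this assay, ureido in place of carbamoyl on a saturated chain carbon, two bonds along the chain from a sulfur, gives a 2.0-fold higher number from compound 3 to compound 4 (0.30 log units; within the scatter) and so shows no readable loss at this position, even with the extra nitrogen of the ureido group. Among the compounds shown here, the 2-ureidoethyl group also stands apart from the other sulfur groups, with a 2.4-fold lower number from compound 2 to compound 4 (0.37 log units; beyond the scatter) and a 3.3-fold lower number from compound 1 to compound 4 (0.51 log units; beyond the scatter) as the steps, so compound 3 is no longer the only compound beyond the scatter of compound 1 and compound 2. Nothing given here explains these numbers.

The compounds shown leave open whether a chain ending in an amine or a carboxylic acid would sit with compound 3 and compound 4. They also leave open how a longer chain carrying the ureido group, or a methyl group on the ureido nitrogen, would read in this assay.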